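Benzyl in Place of 4-Chlorophenyl on the Shared Core

The source may report more compounds than this note shows. Statements on the series, on what has been measured and on what is new or still open speak of the compounds shown alone.

Compound 1 `O=C(Cn1cnc([N+](=O)[O-])n1)Nc1ccc(Oc2ccc(Cl)cc2)cc1`: 80000 nM
Compound 2 `O=C(Cn1cnc([N+](=O)[O-])n1)Nc1ccc(-c2ccc(Cl)cc2)cc1`: > 84000 nM (a limit)

Both compounds were tested in an ADME assay on cells (Peritoneal macrophage cell, Mus musculus) for cytotoxicity; on this read-out higher numbers stand for weaker inhibition and lower numbers for stronger inhibition. Compound 2 has no number in this assay, only the limit > 84000 nM.

The next compound is compound 3 `O=C(Cn1cnc([N+](=O)[O-])n1)Nc1ccc(Cc2ccccc2)cc1`, which keeps the shared core and differs from compound 2 in one place: benzyl in place of 4-chlorophenyl on an aromatic carbon. This puts benzyl in place of 4-chlorophenyl on an aromatic carbon.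

Among the measured compounds shown here, one measured step bears on this change, the exchange of 4-chlorophenoxy for 4-chlorophenyl on an aromatic carbon: an at least 1.0-fold higher number from compound 1 to compound 2 (0.02 log units; that floor lies within the scatter). Going by these compounds, that step is only a floor, so its true size remains open. For the measured compounds named here, compound 1 is the only measured number nearby, at 80000 nM. Given the step of an at least 1.0-fold higher number from compound 1 to compound 2 (0.02 log units; that floor lies within the scatter), no step beyond the scatter is expected in this assay, and no firm direction can be expected either.

The estimated change is an at least 1.2-fold lower number from compound 2 to compound 3 (0.07 log units; that floor lies within the scatter). For compound 3 the expected value is 70000 nM, with an estimated range from 25000 nM to 150000 nM.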

Compound 3, half-maximal inhibitory concentration: > 89000 nM
Compound 3: a limit, no number; the forecaster's own chance of this, stated with the estimate: 50%; middle value at least 1.2-fold (0.10 log units) away from the limit.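

Compound 3, like compound 2, gives a limit and not a number in this assay, so benzyl joins 4-chlorophenyl as a second group on this aromatic carbon, para to a large group, that leaves the read-out without a measured value: the limit of > 89000 nM in this assay, at which 1 of the 3 values shown sits.

The step from 4-chlorophenyl to benzyl cannot be read, as both ends of it are limits, and the compounds therefore say nothing about how these two groups compare. Set against the only measured number in the series, benzyl in place of 4-chlorophenoxy gives an at least 1.1-fold higher number from compound 1 to compound 3 (0.04 log units; that floor lies within the scatter), so this exchange, like the one to 4-chlorophenyl, is known only as a floor, and its true size stays open.

Going by these compounds, the actual values of compound 2 and compound 3 remain unknown, and with them whether either group differs from 4-chlorophenoxy by more than the usual scatter. On these data alone, it also remains open whether a different group at this place, such as an amine or a carboxylic acid, would give a measured number in this assay rather than another limit.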